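The compounds below may be only part of what the source reports. "The series", "measured", "known", "first", "only" and "open" are said of these compounds alone.

Working notes on the series.

Compound 1 `CCN1CCN(c2cn(S(=O)(=O)c3ccc(C(C)C)cc3)c3ccccc23)CC1` in an assay on HeLa cells for displacement of a labelled ligand from 5-hydroxytryptamine receptor 6 (Homo sapiens) (a lower number here means a stronger inhibitor, a higher number a weaker inhibitor), gives 8.6 nM. Compound 2 `CCN1CCN(c2cn(S(=O)(=O)c3ccc(C(C)C)cc3)c3ccc(Cl)cc23)CC1` in this assay gives 30.5 nM. The step of a 3.5-fold lower number from compound 2 to compound 1 (0.55 log units; beyond the scatter) corresponds to the change (hydrogen in place of chloro on an aromatic carbon). Compound 3 `CN1CCN(c2cn(S(=O)(=O)c3ccccc3Br)c3cc(Cl)ccc23)CC1` in this assay gives 30.2 nM. Compound 3 and compound 2 differ in more than one place, and the difference between the two cores is not broken down here; their two values show only that they lie within the scatter of each other.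

Compound 4 `CN1CCN(c2cn(S(=O)(=O)c3ccccc3Br)c3ccccc23)CC1` has not yet been measured in this assay. It derives from compound 3 by hydrogen in place of chloro on an aromatic carbon, the same change as that from compound 2 to compound 1, the place being described in the same words for both; among these compounds this change occurs two times in all. The expected step in this assay is a 3.0-fold lower number from compound 3 to compound 4 (0.48 log units; beyond the scatter), set beside the measured 3.5-fold lower number from compound 2 to compound 1 (0.55 log units; beyond the scatter). This expectation rests on the earlier pair through a 3.5-fold lower number from compound 2 to compound 1 (0.55 log units; beyond the scatter), with the reservation that the remainder of compound 3 is not the same as that of compound 2, so a somewhat smaller or larger step than before cannot be excluded. Compound 4 is therefore estimated in this assay at 10 nM, with an expected range from 4 nM to 25 nM.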

Compound 4, inhibition constant: 15.2 nM
Beside the measured number, compound 4's estimate is 1.5-fold (0.18 log units) below it; low and high end bracket the measured number.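

In this assay, hydrogen in place of chloro on an aromatic carbon now gives a 2.0-fold lower number from compound 3 to compound 4 (0.30 log units; within the scatter), and this step can be set directly beside the earlier one: the same change on two cores in this assay, a 3.5-fold lower number (0.55 log units; beyond the scatter) from compound 2 to compound 1 and a 2.0-fold lower number (0.30 log units; within the scatter) from compound 3 to compound 4, 1.8-fold (0.25 log units) apart, within the scatter of two such steps. Within these two pairs the change therefore carries from one core to the other without a step size that can be told apart, although the new step taken alone lies within the scatter and does not by itself separate compound 3 from compound 4. Two pairs do not show that the change would behave alike on further cores, and since the two cores differ in more than one place, they do not show which of those differences, if any, influences the size of the step.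

The compounds shown carry only chloro or hydrogen at this place, so it remains open whether fluoro, methoxy or a nitrile there would fit with these two steps. Also open, on these data alone, is how a longer chain in place of the ethyl or methyl, or an amide or a carboxylic acid in place of the isopropyl or bromo, would read in this assay.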